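The compounds below may be only part of what the source reports. "The series", "measured", "known", "first", "only" and "open" are said of these compounds alone.

Compound 3 `COc1cc(/C=C/C(=O)Nc2ccccc2)ccc1OCCCCCCCCCCN(C)C` is one of three analogues that share a core and vary only in the amine at the end of the chain. In a physicochemical assay for lipophilicity, using the shake flask method, measured as octanol-water partition, at pH 7.4 (on this read-out higher numbers stand for higher lipophilicity and lower numbers for lower lipophilicity), compound 3 gives 1.8, within the scatter of compound 1 `CCN(CC)CCCCOc1ccc(/C=C/C(=O)Nc2ccccc2)cc1OC` at 1.59 and of compound 2 `COc1cc(/C=C/C(=O)Nc2ccccc2)ccc1OCCCCN1CCCC1` at 1.6. Compound 4 `COc1cc(/C=C/C(=O)Nc2ccccc2)ccc1OCCCCCCCCCCN1CCCC1` differs from compound 3 by pyrrolidin-1-yl in place of dimethylamino on a saturated chain carbon, ten or more bonds along the chain from an oxygen on an aromatic ring. The closest measured precedent is a number 0.01 log units higher from compound 1 to compound 2 (within the scatter), a ring closing on the amine with no change beyond the scatter. Compound 3 is expected to carry over, so the step of a number 0.20 log units higher from compound 3 to compound 4 (within the scatter) is expected to stay within the scatter. Compound 4 is therefore estimated at 2 in this assay, with a range from 1.6 to 2.4.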

Compound 4, partition coefficient: 1.86
The estimate for compound 4 lay 0.14 log units above the measured number; measured number inside the range.
By their numbers in this assay, from the lowest: compounds 1, 2, 3 and 4 (each within the scatter of the next).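

In this assay, pyrrolidin-1-yl in place of dimethylamino on a saturated chain carbon, ten or more bonds along the chain from an oxygen on an aromatic ring, gives a number 0.06 log units higher from compound 3 to compound 4 (within the scatter) and so stays inside the scatter at this far place too. With 6-(pyrrolidin-1-yl)hexyl entering, the steps are a number 0.26 log units higher from compound 2 to compound 4 (within the scatter) and a number 0.27 log units higher from compound 1 to compound 4 (within the scatter) and all four compounds still sit within the scatter of their neighbours. No evidence on the reason for these steps is at hand. From the compounds shown here alone, whether a piperidin-1-yl or morpholin-4-yl amine at this place, or a longer chain, would also stay within the scatter remains open.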